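Branched hydroxyalkyl amine on a shared benzimidazole-free core

The source may report more compounds than this note shows. Statements on the series, on what has been measured and on what is new or still open speak of the compounds shown alone.

Measured compounds:
Compound 1 `OCCNCc1nc2c(OCC3CCCCC3)cccc2[nH]1` — 20000 nM
Compound 2 `OCCCCCNCc1nc2c(OCC3CCCCC3)cccc2[nH]1` — in this assay a limit

Compound 1 `OCCNCc1nc2c(OCC3CCCCC3)cccc2[nH]1` gives 20000 nM in an assay on cells for inhibition of interleukin-5 receptor subunit alpha (Mus musculus), read by WST assay, with a stated time of 48 h, in the presence of a further agent that is not named here; on this read-out lower numbers stand for stronger inhibition and higher numbers for weaker inhibition. Compound 2 `OCCCCCNCc1nc2c(OCC3CCCCC3)cccc2[nH]1` reaches only a limit there, and for compound 2 that limit reads > 30000 nM. Among the measured compounds shown here, the single measured step, an at least 1.5-fold higher number from compound 1 to compound 2 (0.17 log units; that floor lies within the scatter), runs toward the weaker end and is bounded by the limit of > 30000 nM in this assay, at which 1 of the 2 values shown sits.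

Compound 3 `CC(C)(CO)NCc1nc2c(OCC3CCCCC3)cccc2[nH]1` is the unmeasured member. It differs from compound 2 by 1-(hydroxymethyl)-1-methylethyl in place of 5-hydroxypentyl on an amine nitrogen. The new group again places the hydroxyl two bonds from the amine nitrogen, as in compound 1. The step from compound 1 to compound 2 bears on this change only loosely, since it compares chain lengths rather than branching. The expected outcome in this assay for compound 3 is a number near that of compound 1, with an expected step of an at least 1.2-fold lower number from compound 2 to compound 3 (0.07 log units; that floor lies within the scatter). Compound 3 is therefore estimated at 25000 nM, within a range from 8000 nM to 60000 nM.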

Compound 3, half-maximal inhibitory concentration: 27500 nM
Beside the measured number, compound 3's estimate is 1.1-fold (0.04 log units) below it; measured number inside the range.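

On the amine nitrogen, 1-(hydroxymethyl)-1-methylethyl in place of 2-hydroxyethyl gives a 1.4-fold higher number from compound 1 to compound 3 (0.14 log units; within the scatter) in this assay, so this branched group and the unbranched one cannot be told apart on this read-out. Set against 5-hydroxypentyl, the same group gives only an at least 1.0-fold lower number from compound 2 to compound 3 (0.03 log units; that floor lies within the scatter), and the far end of that step is a limit and not a number: the limit of > 30000 nM in this assay, at which 1 of the 3 values shown sits. Among the compounds shown here, no step printed for this position lies beyond the scatter, so neither branching nor the change of chain has yet separated any of the three compounds.

From the compounds shown here alone, it remains open whether a piperidine ring on this nitrogen, or a carboxylic acid in place of the hydroxyl, would give a clearly lower number in this assay. Also open, going by these compounds, is what a plain methyl group on that amine nitrogen would give, with no hydroxyl present.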